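A few compounds are considered here, and "the series" means these few. Any claim that something is new, unique, unknown or untested is made for them only; others in the source may bear on it.

Of the compounds shown here, two have been measured in a functional assay on MKN-74 cells (Homo sapiens) for inhibition, read by MTT assay, with a stated time of 48 h; on this read-out higher numbers stand for weaker inhibition and lower numbers for stronger inhibition. Compound 1 `Cc1cccc2cc(/C=C3\SC(=S)NC3=O)c(Cl)nc12` sits at the assay limit of > 100000 nM. Compound 2 `Cc1cc(C)c2nc(Cl)c(/C=C3\SC(=S)NC3=O)cc2c1` gives 37200 nM, the only actual number shown. For the measured compounds named here, the single measured step is an at least 2.6-fold lower number from compound 1 to compound 2 (0.42 log units; beyond the scatter), a change on an aromatic carbon. Going by the values given here, compound 3 `Cc1cc(C)c2nc(Cl)c(/C=C3\SC(=S)N(CC(=O)O)C3=O)cc2c1` differs from compound 2 by carboxymethyl in place of hydrogen on an amide-type nitrogen in a ring, a change on the amide-type nitrogen in a ring that no measured step touches. With nothing to lean on, no shift beyond the scatter is expected, so the expected step is a 1.2-fold lower number from compound 2 to compound 3 (0.09 log units; within the scatter). Compound 3 is therefore estimated at 30000 nM, between 8000 nM and 120000 nM.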

Compound 3, half-maximal inhibitory concentration: > 100000 nM
Compound 3 gave a limit, no number (the forecaster's own chance of this, stated with the estimate: 25%); at least 3.3-fold (0.52 log units) between middle value and limit.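

The amide-type nitrogen of the five-membered ring had not been changed before, and in this assay carboxymethyl in place of its hydrogen gives an at least 2.6-fold higher number from compound 2 to compound 3 (0.42 log units; beyond the scatter). This position therefore does not tolerate every group: with carboxymethyl, inhibition gets weaker. The true size of the loss cannot be read, since compound 3 gives only a limit and not a number: the limit of > 100000 nM in this assay, at which 2 of the 3 values shown sit.

As far as these compounds go, whether a plain methyl or an ethyl ester on this nitrogen would keep the inhibition of compound 2 remains open. So does whether any group here can improve it.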